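A Fluorine Added to the Sulfonyl Aryl of Compound 1

This account rests on a few compounds, and the source may have more. Where it says the series, first, only, none or still open, it means among the compounds named here.

The series rests on a shared core carrying two aryl groups, one on a carbonyl and one on a sulfonyl. Compound 1 `CS(=O)(=O)c1ccc(F)cc1C(=O)N1CCC(N(C2CC2)S(=O)(=O)c2cccc(C(F)(F)F)c2)CC1` gives 560 nM in an assay on HEK293 cells for inhibition of Voltage-dependent N-type calcium channel subunit alpha-1B (Homo sapiens), read by FLIPR and calcium flux, in the presence of a further agent that is not named here (a higher number here means a weaker inhibitor, a lower number a stronger inhibitor), which is the higher of the two numbers measured; the nearest is compound 2 `O=C(c1ccccc1OC(F)(F)F)N1CCC(N(C2CC2)S(=O)(=O)c2cccc(C(F)(F)F)c2)CC1`, with 120 nM in this assay. Going by the values given here, the one measured step, a 4.7-fold lower number from compound 1 to compound 2 (0.67 log units; beyond the scatter), comes from the 2-(trifluoromethoxy)phenyl in place of 5-fluoro-2-(methylsulfonyl)phenyl on a carbonyl carbon, a modest change.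

Compound 3 `CS(=O)(=O)c1ccc(F)cc1C(=O)N1CCC(N(C2CC2)S(=O)(=O)c2cc(C(F)(F)F)ccc2F)CC1` differs from compound 1 elsewhere: fluoro in place of hydrogen on an aromatic carbon, on the sulfonyl side of the core. Among the compounds with values here, no measured step touches that aryl, so the step from compound 1 to compound 2 bears only indirectly, by showing that single aryl substitutions move the number modestly at most. A single fluorine added to an already substituted aryl is expected to give a step within the scatter, a 1.1-fold lower number from compound 1 to compound 3 (0.05 log units; within the scatter). Compound 3 is therefore estimated at 500 nM in this assay, with a range of 200 nM to 1400 nM.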

Compound 3, half-maximal inhibitory concentration: 2500 nM
Beside the measured number, compound 3's estimate is 5.0-fold (0.70 log units) below it; the measured number lies above the stated range.
By their numbers in this assay, from the lowest: compound 2; then compound 1; then compound 3.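

In this assay, the sulfonyl aryl proves sensitive to a single added atom: the change from 3-(trifluoromethyl)phenyl to 2-fluoro-5-(trifluoromethyl)phenyl gives a 4.5-fold higher number from compound 1 to compound 3 (0.65 log units; beyond the scatter) and so makes compound 3 the weaker inhibitor of that pair. This carbon, ortho to a large group and para to a trifluoromethyl group, therefore tolerates even one fluorine poorly in the setting of compound 1, and the sulfonyl side of the shared core joins the carbonyl side as a place where one change moves the number beyond the scatter, here in the opposite direction to a 4.7-fold lower number from compound 1 to compound 2 (0.67 log units; beyond the scatter) on the carbonyl side. Nothing available here accounts for why this fluorine raises the number.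

The compounds shown do not tell whether the loss is peculiar to fluorine or would also follow a chlorine atom, a methyl group or a methoxy group on the same carbon. They also leave open whether the same fluorine would cost as much when the carbonyl carries the 2-(trifluoromethoxy)phenyl group of compound 2 rather than the aryl of compound 1.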